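Replacing the Anilino Link with a Direct Aryl Group

A few compounds are considered here, and "the series" means these few. Any claim that something is new, unique, unknown or untested is made for them only; others in the source may bear on it.

Compound 1 `COc1cc(-c2nn(-c3cccc(NC(=O)Nc4ccc(Cl)c(Cl)c4)c3)cc2-c2ccncc2)ccc1Cl` gives 773 nM in a functional assay on UACC-62 cells (Homo sapiens) for inhibition, read by sulforhodamine B assay, with a stated time of 48 h; on this read-out lower numbers stand for stronger inhibition of growth and higher numbers for weaker inhibition of growth.
Compound 2 `COc1cc(-c2nn(-c3cccc(NC(=O)Nc4cccc(C(F)(F)F)c4)c3)cc2-c2ccncc2)ccc1Cl` gives 725 nM in this assay.

Compound 2 holds the lowest of the two numbers, and compound 1 sits within the scatter of it. Compound 3 `COc1cc(-c2nn(-c3cccc(NC(=O)c4ccc(Cl)c(C(F)(F)F)c4)c3)cc2-c2ccncc2)ccc1Cl` differs from compound 2 by 4-chloro-3-(trifluoromethyl)phenyl in place of (3-(trifluoromethyl)phenyl)amino on a carbonyl carbon. Within the data shown here, the only measured step, a 1.1-fold lower number from compound 1 to compound 2 (0.03 log units; within the scatter), exchanges one aryl group for another on the amide-type nitrogen and bears only loosely on this change, which removes the amino link itself; no step tests that. Compound 3 is therefore expected near 1000 nM, between 300 nM and 3500 nM, a step of a 1.4-fold higher number from compound 2 to compound 3 (0.14 log units; within the scatter) that is expected, not known.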

Compound 3, concentration for 50% growth inhibition: 2100 nM
For compound 3 the middle estimate is 2.1-fold (0.32 log units) below the measured one; measured number inside the range.
By their numbers in this assay, from the lowest: compounds 2 and 1 (each within the scatter of the next); then compound 3.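

Exchanging the (3-(trifluoromethyl)phenyl)amino group on the carbonyl carbon for 4-chloro-3-(trifluoromethyl)phenyl gives a 2.9-fold higher number from compound 2 to compound 3 (0.46 log units; beyond the scatter) in this assay, and the exchange from the (3,4-dichlorophenyl)amino group gives a 2.7-fold higher number from compound 1 to compound 3 (0.43 log units; beyond the scatter). Unlike the earlier exchange of one aryl group for another, this change moves the number beyond the scatter, so growth inhibition at this position is sensitive to it. No available evidence accounts for this shift. These steps cannot separate losing the amino link from adding the chlorine. On these data alone, whether a methylene link in place of the amino link would restore the numbers of compound 2 also remains open.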